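Replacing a fluorophenyl amide with a phenylcyclopropyl amide

The compounds below may be only part of what the source reports. "The series", "measured", "known", "first", "only" and "open" are said of these compounds alone.

Three measured compounds share one core bearing two amide groups. Compound 1 `O=C(Nc1cccc(NC(=O)c2cccc(Cl)c2)c1)c1ccc(Cl)cc1` carries a 4-chlorophenyl on one carbonyl carbon. In an in vitro functional assay on HEK293-A cells for antagonist activity at metabotropic glutamate receptor 5 (Rattus norvegicus), read by calcium flux (on this read-out lower numbers stand for stronger inhibition and higher numbers for weaker inhibition), compound 1 gives > 30000 nM, which is a limit of the assay rather than a number. Compound 2 `O=C(Nc1cccc(NC(=O)c2ccc(Cl)c(Cl)c2)c1)c1cccc(Cl)c1` adds a second chloro on an aromatic carbon. In this assay compound 2 gives > 30000 nM, again only a limit. Compound 3 `O=C(Nc1cccc(NC(=O)c2cccc(Cl)c2)c1)c1cccc(F)c1` has a 3-fluorophenyl on that carbonyl carbon. In this assay compound 3 gives > 30000 nM, also a limit. All three values sit at the limit of > 30000 nM in this assay, at which 3 of the 3 values shown sit, so compound 3 stands level with the other two and no ordering among them can be read. The steps among them are a step that the two limits leave unreadable from compound 1 to compound 2, a step that the two limits leave unreadable from compound 1 to compound 3 and a step that the two limits leave unreadable from compound 2 to compound 3; none has a readable size.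

Compound 4 `O=C(Nc1cccc(NC(=O)C2CC2c2ccccc2)c1)c1cccc(Cl)c1` differs from compound 3 by 2-phenylcyclopropyl in place of 3-fluorophenyl on a carbonyl carbon. Going by the values given here, no measured step speaks to this change, and no measured value is a number, so the expectation rests on the limit alone. The estimated step from compound 3 to compound 4 is an at least 2.0-fold lower number from compound 3 to compound 4 (0.30 log units; that floor lies within the scatter), with the probable outcome being another limit. Compound 4 is therefore expected to give roughly 15000 nM, within a wide range from 2000 nM to 100000 nM.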

Compound 4, half-maximal inhibitory concentration: > 30000 nM
Compound 4 gave a limit, no number; the forecaster's own chance of this, stated with the estimate: 60%; middle value at least 2.0-fold (0.30 log units) from the limit.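

In this assay compound 4 gives > 30000 nM, which is a limit and not a number. Its steps from compound 1, compound 2 and compound 3 cannot be read, because all four compounds share one limit: the limit of > 30000 nM in this assay, at which 4 of the 4 values shown sit.

The compounds shown leave open how weak each of the four truly is, and whether any change on the shared core gives a measurable value.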